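The compounds below may be only part of what the source reports. "The series", "measured", "known", "first", "only" and "open" are said of these compounds alone.

The measured compounds:

- compound 1, `C/C(=C\c1cc(-c2ccccc2)co1)C(N)=O`; in a functional assay on BGC-823 cells (Homo sapiens) for cytotoxicity, read by CCK-8 assay, with a stated time of 24 h (a higher number here means a weaker inhibitor, a lower number a stronger inhibitor), compound 1 gives > 50000 nM, a limit of the assay and not a number.
- compound 2, `C/C(=C\c1cc(-c2ccc(C)cc2)co1)C(N)=O`; in this assay compound 2 gives > 50000 nM, again a limit.
- compound 3, `C/C(=C\c1nc(-c2ccccc2)cs1)C(N)=O`; in this assay compound 3 gives > 50000 nM, also a limit.

From compound 1 to compound 2 the change is methyl in place of hydrogen on an aromatic carbon. The step it made, a step that the two limits leave unreadable from compound 1 to compound 2, cannot be read, since both values are limits. Compound 3 carries a different core from compound 1; the difference between the two cores is not broken down here. Compound 3 stands only as a limit, as do the two other values shown, and the limit of > 50000 nM in this assay, at which 3 of the 3 values shown sit, is all the evidence there is on the measured steps.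

Compound 4, `C/C(=C\c1nc(-c2ccc(C)cc2)cs1)C(N)=O`, is not yet measured. It differs from compound 3 by methyl in place of hydrogen on an aromatic carbon, the same change as that from compound 1 to compound 2, at a place described in the same words. Going by the values given here, because the limit of > 50000 nM in this assay, at which 3 of the 3 values shown sit, shows every measured compound at the limit, including both ends of the one earlier step of this kind, the step from compound 3 to compound 4 in this assay is expected to be small, a step that the limit leaves unreadable from compound 3 to compound 4. Compound 4 is accordingly estimated at 60000 nM, between 20000 nM and 200000 nM, most likely reported as a limit again.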

Compound 4, half-maximal inhibitory concentration: > 50000 nM
Compound 4 ended at the assay's limit; the forecaster's own chance of this, stated with the estimate: 85%; the middle value is on the limit's open side.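

In this assay compound 4 gives > 50000 nM, a limit of the assay and not a number. The step from compound 3 to compound 4 cannot be read, as the values at both ends are limits. The compounds shown leave open how strong any of them is, and whether methyl in place of hydrogen on an aromatic carbon changes the result in this assay at all: the limit of > 50000 nM in this assay, at which 4 of the 4 values shown sit.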